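Tert-butyl in place of tert-butoxy on the carbonyl carbon

The compounds below may be only part of what the source reports. "The series", "measured", "known", "first", "only" and "open" are said of these compounds alone.

Compound 3 `CCCCOC(=O)CNC(=O)[C@H](CSc1ccc([N+](=O)[O-])cc1[N+](=O)[O-])NC(=O)CC[C@H](NC(=O)OC(C)(C)C)C(=O)OCCCC` gives 70.4 uM in a toxicity assay on KB cells (Homo sapiens) for cytotoxicity, read by fluorescence, with a stated time of 3 days (a lower number here means that less compound is needed, a higher number that more compound is needed for the effect), the highest of the two numbers measured there. Its nearest neighbour is compound 1 `CCCCOC(=O)CNC(=O)[C@H](CSc1ccc([N+](=O)[O-])cc1[N+](=O)[O-])NC(=O)CC[C@H](NC(=O)CC(C)C)C(=O)OCCCC` with 59.6 uM, and the step of a 1.2-fold higher number from compound 1 to compound 3 (0.07 log units; within the scatter) stays within the scatter. Compound 2 `CCCCOC(=O)CNC(=O)[C@H](CSc1ccc([N+](=O)[O-])cc1[N+](=O)[O-])NC(=O)CC[C@H](Nc1ccc([N+](=O)[O-])cc1[N+](=O)[O-])C(=O)OCCCC` reaches only the limit > 300 uM in this assay. Among the measured compounds shown here, the step of an at least 4.2-fold lower number from compound 2 to compound 3 (0.62 log units; beyond the scatter) is the one change here that clearly moved the number.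

Compound 4 `CCCCOC(=O)CNC(=O)[C@H](CSc1ccc([N+](=O)[O-])cc1[N+](=O)[O-])NC(=O)CC[C@H](NC(=O)C(C)(C)C)C(=O)OCCCC` differs from compound 3 only at the carbonyl carbon: tert-butyl in place of tert-butoxy on a carbonyl carbon. For the measured compounds named here, the one measured step at this same carbon, a 1.2-fold higher number from compound 1 to compound 3 (0.07 log units; within the scatter), was within the scatter, so the exchange of tert-butoxy for tert-butyl is expected to leave this assay about unchanged, a step of a 1.1-fold lower number from compound 3 to compound 4 (0.03 log units; within the scatter). Compound 4 is therefore estimated at 65 uM, between 35 uM and 130 uM.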

Compound 4, concentration for half-maximal effect: 83.4 uM
Beside the measured number, compound 4's estimate is 1.3-fold (0.11 log units) below it, within the range that was stated.
By their numbers in this assay, from the lowest: compounds 1, 3 and 4 (each within the scatter of the next). At a limit, above all of these: compound 2.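

In this assay, the new tert-butyl group adds a third carbonyl group on this amine nitrogen, and the steps of a 1.2-fold higher number from compound 3 to compound 4 (0.07 log units; within the scatter) and a 1.4-fold higher number from compound 1 to compound 4 (0.15 log units; within the scatter) leave tert-butyl, tert-butoxy and isobutyl on the carbonyl carbon not told apart. Only the 2,4-dinitrophenyl group stands apart, with an at least 3.5-fold lower number from compound 2 to compound 4 (0.55 log units; beyond the scatter). The value of compound 2 is a limit, not a number: the limit of > 300 uM in this assay, at which 1 of the 4 values shown sits.

As far as these compounds go, what a free amine on this nitrogen would give stays open. So does the effect of a longer chain on the carbonyl carbon.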